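The compounds below may be only part of what the source reports. "The series", "measured", "known", "first", "only" and "open" are said of these compounds alone.

Compound 3 `CN1CCN(CCCOc2cccc3nc(Nc4ccc(F)c(F)c4)ccc23)CC1` gives 7090 nM in a functional assay on cells (Panel leukemia (Carcinoma cell lines), Homo sapiens) for inhibition, read by sulforhodamine B assay, with a stated time of 48 h (a lower number here means a stronger inhibitor of growth, a higher number a weaker inhibitor of growth), the highest of the three numbers measured, while compound 2 `CN1CCN(CCCOc2cccc3nc(Nc4ccc(Cl)c(F)c4)ccc23)CC1` gives 4280 nM and compound 1 `CN1CCN(CCCOc2cccc3nc(Nc4ccc(Cl)c(C(F)(F)F)c4)ccc23)CC1` gives 3480 nM. Compound 4 `CN1CCN(CCCOc2cccc3nc(Nc4cc(Cl)cc(Cl)c4)ccc23)CC1` has not been measured; the change from compound 3 is 3,5-dichlorophenyl in place of 3,4-difluorophenyl on a nitrogen on an aromatic ring. Among the compounds with values here, the steps that bear on it are a 1.7-fold higher number from compound 2 to compound 3 (0.22 log units; within the scatter) and a 2.0-fold higher number from compound 1 to compound 3 (0.31 log units; beyond the scatter), so within this small set chlorine on the phenyl ring has gone with the lower numbers, though no measured pair isolates the move of a halogen to the 3,5-pattern. Compound 4 is therefore expected to give a somewhat lower number than compound 3, a step of a 1.8-fold lower number from compound 3 to compound 4 (0.25 log units; within the scatter), with an estimated value of 4000 nM and a likely range from 1800 nM to 9000 nM.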

Compound 4, concentration for total growth inhibition: 3960 nM
Compound 4: the middle estimate sits 1.0-fold (0.00 log units) above what was measured; the measured number falls inside the stated range.
By their numbers in this assay, from the lowest: compounds 1, 4, 2 and 3 (each within the scatter of the next, the first and the last beyond it).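

Within the data shown here, compound 4 is the first here without a 3,4-substitution pattern on the phenyl ring, and in this assay its 3,5-dichlorophenyl group cannot be separated from any of the three earlier groups: the steps of a 1.8-fold lower number from compound 3 to compound 4 (0.25 log units; within the scatter) and a 1.1-fold lower number from compound 2 to compound 4 (0.03 log units; within the scatter) and a 1.1-fold higher number from compound 1 to compound 4 (0.06 log units; within the scatter) all lie within the scatter. The position on the nitrogen therefore accepts this different halogen pattern without a readable change, and compound 4 does not settle where it belongs within the span from compound 1 to compound 3. Nothing given here accounts for these numbers. On these data alone, what remains open is whether 3,5-difluorophenyl would separate the halogen from its pattern, and how an unsubstituted phenyl or a 3,5-dimethoxyphenyl group would compare.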